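A 1,1-dimethylpentyl chain on compound 1

A few compounds are considered here, and "the series" means these few. Any claim that something is new, unique, unknown or untested is made for them only; others in the source may bear on it.

Going by the values given here, in a functional assay on the whole organism (strain Hartley) for inhibition, with Cavia porcellus as the target, with stated times of 2 min and 15 min (on this read-out lower numbers stand for an effect already at smaller amounts and higher numbers for an effect only at larger amounts of compound), compound 1 `CCCCC[C@H](O)/C=C/C1CCC(=O)[C@@H]1CCCCSCC(=O)O` gives 0.00514 mg/kg, the lowest number so far. Compound 2 `CCCCC[C@](C)(O)/C=C/C1CCC(=O)[C@@H]1CCCCSCC(=O)O` gives 0.0193 mg/kg. Compound 3 `CCCCC(C)(C)[C@H](O)/C=C/C1CCC(=O)[C@@H]1CCCCSCC(=O)O` is not yet measured and differs from compound 1 by 1,1-dimethylpentyl in place of pentyl on a saturated chain carbon bound to a double-bonded chain carbon and an oxygen on a saturated carbon. Among the compounds with values here, only one measured step bears on this, and only indirectly because it is a different change: a 3.8-fold higher number from compound 1 to compound 2 (0.57 log units; beyond the scatter), which is modest but beyond the scatter. A similarly modest rise in this assay therefore seems likely, though no change beyond the scatter remains possible. The estimated step is a 2.1-fold higher number from compound 1 to compound 3 (0.33 log units; beyond the scatter). For compound 3 the expected value is 0.011 mg/kg, with an estimated range of 0.003 mg/kg to 0.04 mg/kg.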

Compound 3, dose for half-maximal effect: 0.604 mg/kg
Beside the measured number, compound 3's estimate is 55-fold (1.74 log units) below it; measured number outside the range, above it.
By their numbers in this assay, from the lowest: compound 1; then compound 2; then compound 3.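

In this assay, going by these compounds alone, the swap of pentyl for 1,1-dimethylpentyl is a large step (a 120-fold higher number from compound 1 to compound 3 (2.07 log units; beyond the scatter)), whereas the only earlier change was modest (a 3.8-fold higher number from compound 1 to compound 2 (0.57 log units; beyond the scatter)). The place on a saturated chain carbon bound to a double-bonded chain carbon and an oxygen on a saturated carbon therefore responds far more sharply to this change than that earlier step had indicated. Nothing available explains the size of this step.

Still open, from the compounds shown here alone, is whether 1-methylpentyl, with a single added methyl, would give a smaller step. Going by these compounds, it is also open whether a longer unbranched chain, such as heptyl, would do the same.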